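Amide Replacement on the Pyrrolidine-Linked Core

The source may hold more compounds than are shown below. What is called first, only, known or untested is meant among the compounds shown, and "the series" means these compounds.

Measured compounds:
compound 1 `CN(CCCn1ccnc1)C(=O)[C@@H]1CCCN1c1nccc(Nc2ccccc2)n1` in an assay on isolated protein for inhibition of calcium/calmodulin-dependent protein kinase type II subunit alpha (Homo sapiens), read by HTRF, tested at 10 uM; on this read-out lower numbers stand for less inhibition and higher numbers for more inhibition at the one concentration tested (going by the name of the read-out): compound 1 gives 0%
compound 2 `CC(=O)CCCCC(=O)N1CCN(c2nccc(Oc3cccc(C)c3)n2)CC1`: compound 2 gives 0%
compound 3 `Cc1cccc(Nc2ncnc3c2CN(C(=O)c2ccc(N(C)C)c4ccccc24)CC3)c1`: compound 3 gives 0%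

On these numbers compound 1 stands level with compound 2 and compound 3 at the digits reported; the nearest of the two is compound 2 and the furthest is compound 3, but in neither case does the gap amount to a change beyond the scatter. None of the three compounds shows inhibition in this assay at the single concentration tested.

Compound 4 `COC[C@@H]1CCCN1C(=O)[C@@H]1CCCN1c1nccc(Nc2ccccc2)n1` is the next compound to be measured. It differs from compound 1 in one place: 2-(methoxymethyl)pyrrolidin-1-yl in place of (3-(1H-imidazol-1-yl)propyl)(methyl)amino on a carbonyl carbon. The shared core of compound 1 is otherwise kept.

Within the data shown here, no step between measured compounds is available to guide the expectation, and the three measured values all lie at the same level. Compound 4 is therefore expected to give 0% in this assay, with a range from -8% to 12%. The step expected for compound 4 is no change at the digits printed from compound 1 to compound 4 (within the scatter), that is, none beyond the scatter.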

Compound 4, a percentage reported as inhibition, at one concentration (the size of the read-out at that concentration, not a potency): 0%
The estimate for compound 4 equals the measured number at the digits printed; measured number inside the range.
By their numbers in this assay, from the lowest: compounds 1, 2, 3 and 4 (each within the scatter of the next).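

In this assay, placing 2-(methoxymethyl)pyrrolidin-1-yl in place of (3-(1H-imidazol-1-yl)propyl)(methyl)amino on a carbonyl carbon gives no change at the digits printed from compound 1 to compound 4 (within the scatter), the first step available at this position. The five-membered aromatic ring with 2 hetero atoms can thus give way to a five-membered non-aromatic ring with 1 hetero atom, with a defined stereocentre added, without any difference appearing in the read-out, and since compound 1 and compound 4 both show no inhibition, the step cannot reveal any contribution of either group. No available information bears on the reason for this result. On these data alone, it remains open whether a carboxylic acid, a primary amine or a longer chain on this carbonyl carbon would give any inhibition in this assay. Equally open, as far as these compounds go, is whether any group at this place can raise the read-out while the rest of the shared core is kept.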